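The source may hold more compounds than are shown below. What is called first, only, known or untested is meant among the compounds shown, and "the series" means these compounds.

In a functional assay on SF-539 cells (Homo sapiens) for inhibition, read by sulforhodamine B assay, with a stated time of 48 h (a lower number here means a stronger inhibitor of growth, a higher number a weaker inhibitor of growth), the three measured compounds read as follows. Compound 1 `COc1cc(-c2nn(-c3cccc(NC(=O)c4cccc(C(F)(F)F)c4)c3)cc2-c2ccncc2)ccc1Cl` gives 2300 nM. Compound 2 `COc1cc(-c2nn(-c3cccc(NC(=O)Nc4ccc(Cl)c(Cl)c4)c3)cc2-c2ccncc2)ccc1Cl` gives 3080 nM. Compound 3 `O=C(Nc1cccc(-n2cc(-c3ccncc3)c(-c3ccc(Cl)c(O)c3)n2)c1)Nc1ccc(Cl)c(Cl)c1` gives 8970 nM.

Compound 2 holds the second highest of these three numbers; the gap from compound 1 to compound 2 is small a 1.3-fold higher number from compound 1 to compound 2 (0.13 log units; within the scatter), while the gap from compound 2 to compound 3 is larger a 2.9-fold higher number from compound 2 to compound 3 (0.46 log units; beyond the scatter).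

Compound 4 `COc1cc(-c2nn(-c3cccc(NC(=O)c4ccccc4)c3)cc2-c2ccncc2)ccc1Cl` differs from compound 2 by phenyl in place of (3,4-dichlorophenyl)amino on a carbonyl carbon. For the measured compounds named here, the only step that bears on this is the exchange on the same carbonyl carbon between compound 1 and compound 2 a 1.3-fold higher number from compound 1 to compound 2 (0.13 log units; within the scatter), which stayed within the scatter. Going by the values given here, no measured step removes halogens from that outer ring. The step to compound 4 is therefore expected to stay within the scatter a 1.1-fold higher number from compound 2 to compound 4 (0.06 log units; within the scatter). Compound 4 is estimated at 3500 nM, between 1500 nM and 8000 nM.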

Compound 4, concentration for total growth inhibition: 2880 nM
Compound 4: middle estimate off by 1.2-fold (0.08 log units), on the high side; the measured number falls inside the stated range.
By their numbers in this assay, from the lowest: compounds 1, 4 and 2 (each within the scatter of the next); then compound 3.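

In this assay, the plain phenyl on this carbonyl carbon reads level with both substituted partners (a 1.1-fold lower number from compound 2 to compound 4 (0.03 log units; within the scatter); a 1.3-fold higher number from compound 1 to compound 4 (0.10 log units; within the scatter)). Across these three compounds, neither the (3,4-dichlorophenyl)amino group nor the trifluoromethyl produces a step beyond the scatter, so neither the chlorines, the trifluoromethyl nor the nitrogen on the carbonyl carbon moves the number measurably here. No evidence is available to explain this flat result.

On these data alone, whether an amine or a carboxylic acid on this outer ring would also leave the number in place remains open. So does replacing the phenyl with a cyclohexyl ring.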